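The source may report more compounds than this note shows. Statements on the series, on what has been measured and on what is new or still open speak of the compounds shown alone.

Measured so far:
Compound 1, `CCCCCCCCCO[C@@H]1[C@@H](N)[C@@H](O[C@H]2[C@H](O)[C@@H](O)[C@H](N)C[C@@H]2N)O[C@H](CN)[C@H]1OCCCCCCCCC`: in a toxicity assay on the whole organism (J774 cells) for cytotoxicity, with Mus musculus as the target, read by MTT assay, with a stated time of 24 h, tested at 30 uM (on this read-out higher numbers stand for a weaker effect at the one concentration tested and lower numbers for a stronger effect), compound 1 gives 48.6%.
Compound 2, `CCCCCCCCCO[C@@H]1[C@@H](N)[C@@H](OCC(O)CNCCCN)O[C@H](CN)[C@H]1OCCCCCCCCC`: in this assay compound 2 gives 71.6%.

Of these two numbers compound 2 stands highest, that is, it shows the weaker effect at the one concentration tested. For the measured compounds named here, its only neighbour is compound 1, and the one recorded step between them, a number 23 percentage points higher from compound 1 to compound 2 (beyond the scatter), lies beyond the scatter.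

Compound 3, `CCCCCCCCCO[C@@H]1[C@@H](N)[C@@H](OC[C@@H](O)CN)O[C@H](CN)[C@H]1OCCCCCCCCC`, is not yet measured. It differs from compound 2 in one place: 2-amino-1-hydroxyethyl in place of 2-((3-aminopropyl)amino)-1-hydroxyethyl on a saturated chain carbon bound to an oxygen on a saturated carbon. Going by the values given here, no measured step exchanges exactly these two groups, so the only guide is the step from compound 1 to compound 2, in which a group carrying two amines on a ring gave way to an open chain carrying two amines and the number rose by a modest amount. The change to compound 3 again trims the group on that oxygen, this time to 2-amino-1-hydroxyethyl, and a further rise, smaller than the one seen before, is expected: a number 7.4 percentage points higher from compound 2 to compound 3 (within the scatter). Compound 3 is therefore estimated at 79%, with a range from 60% to 96%.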

Compound 3, a percentage reported as activity, at one concentration (the size of the read-out at that concentration, not a potency): 7.2%
Compound 3: middle estimate off by 71.8 percentage points, on the high side; the measured number lies below the stated range.
By their numbers in this assay, from the lowest: compound 3; then compound 1; then compound 2.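

In this assay this position turns out to be very sensitive to the length of the open chain: cutting 2-((3-aminopropyl)amino)-1-hydroxyethyl back to 2-amino-1-hydroxyethyl gives a number 64.4 percentage points lower from compound 2 to compound 3 (beyond the scatter) and so moves strongly toward the stronger effect. The direction is opposite to that of a number 23 percentage points higher from compound 1 to compound 2 (beyond the scatter) and compound 3 also stands clear of the ring-bearing compound, with a number 41.4 percentage points lower from compound 1 to compound 3 (beyond the scatter) as the step, so swapping the ring for an open chain does not by itself weaken the effect: compound 2 fits that reading and compound 3 goes against it. Nothing available here explains why the shorter group behaves so differently.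

The entering group also carries one defined stereocentre, so the compounds shown cannot separate the loss of the 3-aminopropyl part from the effect of that defined arrangement, and the mirror-image 3-amino-2-hydroxypropyl group would be needed to tell them apart. From the compounds shown here alone, it also remains open where a middle-length group such as 3-((2-aminoethyl)amino)-2-hydroxypropyl would fall, and so whether the number changes gradually with chain length or jumps abruptly.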